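Replacing 3,4-dichlorophenyl with 2,5-dimethylfuran-3-yl

The source may hold more compounds than are shown below. What is called first, only, known or untested is meant among the compounds shown, and "the series" means these compounds.

In an ADME assay on MT4 cells (Homo sapiens) for cytotoxicity, read by MTT assay (a higher number here means that more compound is tolerated, a lower number that less compound is tolerated), compound 1 `Cc1cccc(C(=O)N(C(=S)OCCN2C(=O)c3ccccc3C2=O)c2ccc(Cl)cc2)c1` gives 58000 nM, compound 2 `O=C1c2ccccc2C(=O)N1CCOC(=S)N(C(=O)c1ccc(Cl)cc1Cl)c1ccc(Cl)cc1` gives 18000 nM and compound 3 `O=C1c2ccccc2C(=O)N1CCOC(=S)N(C(=O)c1ccc(Cl)c(Cl)c1)c1ccc(Cl)cc1` gives 35000 nM. Compound 3 thus lies within the scatter of both others. Compound 4 `Cc1cc(C(=O)N(C(=S)OCCN2C(=O)c3ccccc3C2=O)c2ccc(Cl)cc2)c(C)o1` has 2,5-dimethylfuran-3-yl in place of 3,4-dichlorophenyl on a carbonyl carbon. Going by the values given here, no measured compound carries this furan, so the nearest evidence is indirect. The changes on this carbonyl carbon gave a 3.2-fold lower number from compound 1 to compound 2 (0.51 log units; beyond the scatter), a modest step, while a 1.7-fold lower number from compound 1 to compound 3 (0.22 log units; within the scatter) and a 1.9-fold higher number from compound 2 to compound 3 (0.29 log units; within the scatter) stayed within the scatter. With steps this small, no shift beyond the scatter is expected, and the expected change is a 1.2-fold higher number from compound 3 to compound 4 (0.08 log units; within the scatter). The estimate for compound 4 is 42000 nM, with an expected range from 18000 nM to 100000 nM.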

Compound 4, half-maximal cytotoxic concentration: 40000 nM
The estimate for compound 4 lay 1.1-fold (0.02 log units) above the measured number; the measured number falls inside the stated range.
By their numbers in this assay, from the lowest: compounds 2, 3, 4 and 1 (each within the scatter of the next, the first and the last beyond it).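

In this assay, a five-membered aromatic ring with a hetero atom on this carbonyl carbon stays within the scatter of both six-membered rings that carry no 2-chloro group: a 1.1-fold higher number from compound 3 to compound 4 (0.06 log units; within the scatter) and a 1.5-fold lower number from compound 1 to compound 4 (0.16 log units; within the scatter). Only against 2,4-dichlorophenyl does the furan step pass beyond the scatter, and modestly, with a 2.2-fold higher number from compound 2 to compound 4 (0.35 log units; beyond the scatter). No measurement here explains these steps. Still open, as far as these compounds go, is whether a carbonyl carbon bearing an amine, a carboxylic acid or a longer alkyl chain would stay within this same narrow band.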